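Piperidin-4-yl to methyl: one change across two cores

This account rests on a few compounds, and the source may have more. Where it says the series, first, only, none or still open, it means among the compounds named here.

In a functional assay on SK-BR-3 cells (Homo sapiens) for antiproliferative activity, read by MTT assay, with a stated time of 72 h (on this read-out lower numbers stand for stronger inhibition and higher numbers for weaker inhibition), compound 1 `CC(Nc1nc(N)nc2ccc(-c3cnn(C4CCNCC4)c3)cc12)c1c(Cl)ccc(F)c1Cl` gives 1580 nM. Its close relative compound 3 `CC(Nc1nc(N)nc2ccc(-c3cnn(C)c3)cc12)c1c(Cl)ccc(F)c1Cl` carries the change methyl in place of piperidin-4-yl on an aromatic nitrogen and gives 7140 nM, a step of a 4.5-fold higher number from compound 1 to compound 3 (0.66 log units; beyond the scatter). Compound 2 `CC(Oc1ncnc2ccc(-c3cnn(C4CCNCC4)c3)cc12)c1c(Cl)ccc(F)c1Cl` rests on a different core; the difference between the two cores is not broken down here. In this assay compound 2 gives 2500 nM, which lies within the scatter of compound 1. Compound 4 `CC(Oc1ncnc2ccc(-c3cnn(C)c3)cc12)c1c(Cl)ccc(F)c1Cl` has not yet been measured; it differs from compound 2 by methyl in place of piperidin-4-yl on an aromatic nitrogen, the same change that separates compound 1 from compound 3. Because the step of a 4.5-fold higher number from compound 1 to compound 3 (0.66 log units; beyond the scatter) was modest but beyond the scatter, a step of similar size is expected for compound 4, namely a 4.4-fold higher number from compound 2 to compound 4 (0.64 log units; beyond the scatter). Compound 4 is therefore estimated at 11000 nM, with a range from 4500 nM to 28000 nM.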

Compound 4, half-maximal inhibitory concentration: 27200 nM
Estimate against measurement, compound 4: 2.5-fold (0.39 log units) below; the range from low to high includes it.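

In this assay, methyl in place of piperidin-4-yl again raises the number, giving an 11-fold higher number from compound 2 to compound 4 (1.04 log units; beyond the scatter). Set beside the earlier step, the change carries over in direction, and the two steps cannot be told apart in size: the same change on two cores in this assay, a 4.5-fold higher number (0.66 log units; beyond the scatter) from compound 1 to compound 3 and an 11-fold higher number (1.04 log units; beyond the scatter) from compound 2 to compound 4, 2.4-fold (0.38 log units) apart, within the scatter of two such steps. Among these compounds, this rests on only two pairs, so it shows transfer between these two cores alone, and it does not show that the step truly differs in size from one core to the other.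

The compounds shown leave open whether the higher number follows from losing the ring or from losing its amine, as only piperidin-4-yl and methyl are compared on the aromatic nitrogen. An aminoethyl chain or a cyclohexyl ring at that place would separate the two.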